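The source may report more compounds than this note shows. Statements on the series, on what has been measured and on what is new or still open speak of the compounds shown alone.

Working notes on the series in an ADME assay on MRC5 cells (Homo sapiens) for inhibition, with a stated time of 72 h; a lower number here means that less compound is needed, a higher number that more compound is needed for the effect. Compound 1 `CO[C@H]1CC[C@H](NC(=O)c2n[nH]cc2NC(=O)c2cnc3ccccn23)CC1` gives 5900 nM in this assay. Compound 3 `CCc1ccccc1C(=O)Nc1c[nH]nc1C(=O)N[C@H]1CC[C@H](OC)CC1` gives 3400 nM in this assay. Among the measured compounds shown here, the step of a 1.7-fold lower number from compound 1 to compound 3 (0.24 log units; within the scatter) is the only step among the measured compounds, and it sits on the carbonyl carbon of the other amide. Compound 2 `COc1cccc(OC)c1C(=O)Nc1c[nH]nc1C(=O)NN1CCOCC1` gives only a limit in this assay, > 50000 nM. Compound 2 therefore stands at the limit of > 50000 nM in this assay, at which 1 of the 3 values shown sits, with no number of its own. Compound 4 `COc1cccc(OC)c1C(=O)Nc1c[nH]nc1C(=O)NCCCN(C)C` is not yet measured. It differs from compound 2 by 3-(dimethylamino)propyl in place of morpholin-4-yl on an amide-type nitrogen. For the measured compounds named here, no measured step touches this amide-type nitrogen: the step from compound 1 to compound 3 lies on the other carbonyl and, being within the scatter, gives no lead on the size or direction to expect here. Going by the values given here, the only anchor is compound 2, which sits at the limit. Compound 4 is expected to give about 40000 nM in this assay, within 10000 nM to 100000 nM. For compound 4 the estimated step of an at least 1.2-fold lower number from compound 2 to compound 4 (0.09 log units; that floor lies within the scatter) is expected to be small, and it is likely that compound 4 is again reported only as a limit.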

Compound 4, half-maximal effective concentration: > 50000 nM
Compound 4: only a limit was reported (the forecaster's own chance of this, stated with the estimate: 60%); middle value at least 1.2-fold (0.09 log units) from the limit.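

Compound 4, like compound 2, is reported only as a limit, so the step between compound 2 and compound 4 cannot be read: the limit of > 50000 nM in this assay, at which 2 of the 4 values shown sit.

The compounds shown leave open how 3-(dimethylamino)propyl and morpholin-4-yl on the amide-type nitrogen compare in this assay, and whether any group at that place gives a measured number.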